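From a Methyl End to a Diethylamino End

The compounds below may be only part of what the source reports. "The series", "measured", "known", "first", "only" and "open" are said of these compounds alone.

Compound 3 (`CCC(=O)NCC(=O)N(C)c1ccc(Cl)cc1C(=O)c1ccccc1Cl`) reads 36 mg/kg in a functional assay on the whole organism with Mus musculus as the target, in the rotarod test (on this read-out lower numbers stand for an effect already at smaller amounts and higher numbers for an effect only at larger amounts of compound), and holds the higher of the two actual numbers available. Compound 2 (`CC(NC(=O)CN)C(=O)N(C)c1ccc(Cl)cc1C(=O)c1ccccc1Cl`) reads 8.5 mg/kg in this assay and sits on the lower side. Compound 1 (`CN1CCN(CC(=O)NCC(=O)N(C)c2ccc(Cl)cc2C(=O)c2ccccc2Cl)CC1`) reads > 100 mg/kg as a limit of the assay and not a number.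

Compound 4 (`CCN(CC)CC(=O)NCC(=O)N(C)c1ccc(Cl)cc1C(=O)c1ccccc1Cl`) has not yet been measured. It carries diethylamino in place of methyl on a saturated chain carbon bound to a carbonyl carbon, a change counted as diethylamino in place of methyl on a saturated chain carbon bound to a carbonyl carbon in the structures.

Among the measured compounds shown here, the closest precedent at this place is an at least 2.7-fold lower number from compound 1 to compound 3 (0.44 log units; beyond the scatter) as methyl takes the place of 4-methylpiperazin-1-yl, which hints that the larger group raises the number. The other measured step, a 4.2-fold higher number from compound 2 to compound 3 (0.63 log units; beyond the scatter) with (propanoylamino)methyl in place of 1-(((aminomethyl)carbonyl)amino)ethyl on a carbonyl carbon, concerns a different change and gives no support for a rise. With the two steps pulling apart, only a drift toward a higher number is expected, probably not clearly beyond the scatter.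

The expected change is a 1.7-fold higher number from compound 3 to compound 4 (0.22 log units; within the scatter) as estimated here. The estimate for compound 4 is 60 mg/kg with an expected range from 18 mg/kg to 160 mg/kg on this read-out.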

Compound 4, dose for half-maximal effect: 34 mg/kg
Beside the measured number, compound 4's estimate is 1.8-fold (0.25 log units) above it; measured number inside the range.
By their numbers in this assay, from the lowest: compound 2; then compounds 4 and 3 (each within the scatter of the next). At a limit, above all of these: compound 1.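

In this assay, diethylamino in place of methyl on a saturated chain carbon bound to a carbonyl carbon gives a 1.1-fold lower number from compound 3 to compound 4 (0.02 log units; within the scatter) and so stays inside the scatter, which shows that this place tolerates a much larger open-chain end carrying a nitrogen with no reading beyond the scatter. The gap persists as a 4.0-fold higher number from compound 2 to compound 4 (0.60 log units; beyond the scatter), just as it did for compound 3, so this exchange of end groups does nothing to close it. Compound 1 holds only a limit of the assay and not a number, so the step with diethylamino in place of 4-methylpiperazin-1-yl, an at least 2.9-fold lower number from compound 1 to compound 4 (0.46 log units; beyond the scatter) as printed, is a bound and says only that the two end groups part beyond the scatter: the limit of > 100 mg/kg in this assay, at which 1 of the 4 values shown sits.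

The compounds shown leave open whether a small end such as dimethylamino or a free primary amine at this same place, on the chain of compound 3, would approach compound 2, or whether the extra methyl on the chain of compound 2 matters more. They also do not tell whether a morpholine ring here would read like diethylamino or like 4-methylpiperazin-1-yl.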